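Chloro for fluoro on the aminobenzyl sulfonyl group

The compounds below may be only part of what the source reports. "The series", "measured", "known", "first", "only" and "open" are said of these compounds alone.

In an in vivo ADME assay on the whole organism for pharmacokinetics, with Rattus norvegicus as the target, at a dose of 10 mg/kg by the oral route (a lower number here means less compound in the circulation, a higher number more compound in the circulation at the dose given), compound 1 `CC1(COc2c(N3CCN(S(=O)(=O)Cc4ccc(N)c(C(F)(F)F)c4)CC3)cnn(-c3cccc(Cl)c3)c2=O)CC1` gives 719 nM and compound 2 `CC1(COc2c(N3CCN(S(=O)(=O)Cc4ccc(N)c(F)c4)CC3)cnn(-c3cc(F)cc(F)c3)c2=O)CC1` gives 550 nM. These two values lie within the scatter of each other, so compound 2 stands level with compound 1 on the numbers available.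

Compound 3 `CC1(COc2c(N3CCN(S(=O)(=O)Cc4ccc(N)c(Cl)c4)CC3)cnn(-c3cc(F)cc(F)c3)c2=O)CC1` has not yet been measured in this assay. It differs from compound 2 in one place: chloro in place of fluoro on an aromatic carbon. This puts chloro in place of fluoro on an aromatic carbon, ortho to an amino group and meta to a large group, turning 4-amino-3-fluorobenzyl into 4-amino-3-chlorobenzyl.

Among the compounds with values here, no two measured compounds differ in only one place, so the series gives no direct reading of this exchange. Within the data shown here, the only guide is the closeness of compound 1 at 719 nM and compound 2 at 550 nM. The expected change, a 1.1-fold higher number from compound 2 to compound 3 (0.04 log units; within the scatter), stays within the scatter and has no firm direction. Compound 3 is estimated at 600 nM, with an expected range of 260 nM to 1400 nM.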

Compound 3, maximal plasma concentration: 569 nM
The estimate for compound 3 lay 1.1-fold (0.02 log units) above the measured number, within the range that was stated.
By their numbers in this assay, from the lowest: compounds 2, 3 and 1 (each within the scatter of the next).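

The exchange of fluoro for chloro on an aromatic carbon, ortho to an amino group and meta to a large group, now has a direct reading in this assay: it gives a 1.0-fold higher number from compound 2 to compound 3 (0.01 log units; within the scatter). Compounds 2 and 3 are the only pair shown that differ in one place, and on maximal plasma concentration 4-amino-3-fluorobenzyl and 4-amino-3-chlorobenzyl stand level at this position, with the rest of the structure held constant. No measured property of these compounds is available to account for this reading.

Whether the level reading extends beyond these two halogens stays open, as the compounds shown give no reading at this position for hydrogen, a methyl group, a methoxy group or a nitrile. Compound 1 carries trifluoromethyl at this position but also differs elsewhere in the structure, so its step to either of the others cannot be read, and the reading of chloro for fluoro rests on a single pair on the 3,5-difluorophenyl-bearing core of compound 2.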